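Terminal ring exchange on the shared core: toward compound 4

The source may hold more compounds than are shown below. What is called first, only, known or untested is meant among the compounds shown, and "the series" means these compounds.

Measured in a functional assay on HEK293 cells for agonist activity at Bombesin receptor subtype-3 (Mus musculus), read by luminescence and calcium flux, with a stated time of 10 min; on this read-out lower numbers stand for an effect already at smaller amounts and higher numbers for an effect only at larger amounts of compound:
compound 1, `CCC(C)(C)Cc1c[nH]c(CCc2ccc(-c3ccncc3)cc2)n1`: compound 1 gives 103 nM
compound 2, `CCC(C)(C)Cc1c[nH]c(CCc2ccc(-n3cccn3)cc2)n1`: compound 2 gives 113 nM
compound 3, `CCC(C)(C)Cc1c[nH]c(CCc2ccc(-n3ccnn3)cc2)n1`: compound 3 gives 111 nM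

The three measured compounds differ only in the ring attached para to the large group. Every step among them is small: a 1.1-fold higher number from compound 1 to compound 2 (0.04 log units; within the scatter), a 1.1-fold higher number from compound 1 to compound 3 (0.03 log units; within the scatter) and a 1.0-fold lower number from compound 2 to compound 3 (0.01 log units; within the scatter). Compound 3 thus sits second highest of the three numbers, with compound 2 nearest and compound 1 furthest, and neither gap exceeds the scatter, so no order among the three can be read.

Compound 4, `CCC(C)(C)Cc1c[nH]c(CCc2ccc(-c3cccc(C#N)n3)cc2)n1`, is not yet measured. The change from compound 3 is 6-cyanopyridin-2-yl in place of 1H-1,2,3-triazol-1-yl on an aromatic carbon. The steps that bear on it are the three exchanges at the same place described above, all within the scatter, though none of them introduced a six-membered ring carrying a nitrile. On that basis no step beyond the scatter is expected in this assay, in either direction, with a wider range allowed for the unprecedented group.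

Compound 4 is therefore expected to give about 110 nM, between 40 nM and 320 nM, which means an expected step of a 1.0-fold lower number from compound 3 to compound 4 (0.00 log units; within the scatter).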

Compound 4, half-maximal effective concentration: 115 nM
Compound 4: middle estimate off by 1.0-fold (0.02 log units), on the low side; measured number inside the range.
By their numbers in this assay, from the lowest: compounds 1, 3, 2 and 4 (each within the scatter of the next).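

In this assay, for the compounds shown here, 6-cyanopyridin-2-yl, the only group here with a triple bond outside aromatic rings, stays within the scatter of all three earlier groups at this place, on an aromatic carbon para to a large group (a 1.0-fold higher number from compound 3 to compound 4 (0.02 log units; within the scatter); a 1.0-fold higher number from compound 2 to compound 4 (0.01 log units; within the scatter); a 1.1-fold higher number from compound 1 to compound 4 (0.05 log units; within the scatter)). The exchange of 1H-1,2,3-triazol-1-yl, with 5 heavy atoms, for this group with 8 heavy atoms therefore brings no readable step, so among these four compounds neither the ring size, nor the number of ring hetero atoms, nor the presence of a nitrile separates the values. Nothing measured is at hand to explain why these exchanges leave the values so close.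

Whether an amine, a carboxylic acid or a longer chain at this place would give a step beyond the scatter stays open, as no step of that size appears among the compounds shown. Also open, from the compounds shown here alone, is whether the same ring exchanges would stay this close with a different group in place of the rest of the shared core.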